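A few compounds are considered here, and "the series" means these few. Any claim that something is new, unique, unknown or untested is made for them only; others in the source may bear on it.

Measured in a functional assay (muscle tissue) with Cavia porcellus as the target; a higher number here means that more compound is needed for the effect, a lower number that less compound is needed:
- compound 1 `COC(=O)C1=C(C)N=C(C)/C(=C(\O)OC)C1c1cc(Cl)cc(Cl)c1`: 93.3 nM
- compound 2 `COC(=O)C1=C(C)N=C(C)/C(=C(\O)OC)C1c1c(Cl)cccc1Cl`: 1.91 nM

Compound 2, at 1.91 nM, has the lower of the two numbers. The next step leads to compound 3 `COC(=O)C1=C(C)N=C(C)/C(=C(\O)OC)C1c1cccc(F)c1`, which has not yet been measured: 3-fluorophenyl in place of 2,6-dichlorophenyl on a saturated ring carbon. Thus 3-fluorophenyl stands in place of 2,6-dichlorophenyl on a saturated ring carbon. Among the compounds with values here, only one measured step bears on this change, a 49-fold lower number from compound 1 to compound 2 (1.69 log units; beyond the scatter), which is large and beyond the scatter. It also turns on 2,6-dichlorophenyl, but that group is gained there and lost here. Compound 3 has no 2,6-dichlorophenyl, like compound 1 at 93.3 nM, so a large rise in this assay is expected. Within the data shown here, no measured compound carries fluorine, so the size remains uncertain. The expected step is a 21-fold higher number from compound 2 to compound 3 (1.32 log units; beyond the scatter). For compound 3 the estimated value is 40 nM, with an expected range of 8 nM to 200 nM.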

Compound 3, half-maximal effective concentration: 20.9 nM
Estimate against measurement, compound 3: 1.9-fold (0.28 log units) above; low and high end bracket the measured number.
By their numbers in this assay, from the lowest: compound 2; then compound 3; then compound 1.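

In this assay, replacing 2,6-dichlorophenyl with 3-fluorophenyl on the saturated ring carbon gives an 11-fold higher number from compound 2 to compound 3 (1.04 log units; beyond the scatter) as a large step, so the 2,6-dichlorophenyl group still marks the lowest number of the three compounds. Replacing 3,5-dichlorophenyl with 3-fluorophenyl gives a 4.5-fold lower number from compound 1 to compound 3 (0.65 log units; beyond the scatter) as a modest step, which shows that the two compounds without 2,6-dichlorophenyl also differ from each other and that the result depends on more than the absence of that group. Nothing measured here explains either step.

Both steps change the halogen and its ring placement together, so the contribution of each remains unresolved. As far as these compounds go, how a 2-chlorophenyl or a 3-nitrophenyl group on this ring carbon would stand in this assay also remains open.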